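This account rests on a few compounds, and the source may have more. Where it says the series, first, only, none or still open, it means among the compounds named here.

Compound 1 `Cc1cc(-c2cnc(NCc3c(F)ccc4c3CCO4)c3cn[nH]c(=O)c23)n(C)n1` was tested in a physicochemical assay for solubility, read by LC-MS, in phosphate buffer, with a stated time of 24 h, at pH 7.4; on this read-out lower numbers stand for lower solubility and higher numbers for higher solubility. Compound 1 gives 1000 nM, the lowest of the two numbers shown. Compound 3 `Cc1ncccc1-c1cnc(NCc2c(F)ccc3c2CCO3)c2nn(CC#N)c(=O)n12` gives 4000 nM, and the gap to compound 1 is beyond the usual scatter. Compound 2 `Cc1ncccc1-c1cnc(NCc2c(F)ccc3c2CCO3)n2c(=O)[nH]nc12` gives only a limit, < 2000 nM; this is the limit of < 2000 nM in this assay, at which 1 of the 3 values shown sits. Compound 4 `Cc1nn(C)cc1-c1cnc(NCc2c(F)ccc3c2CCO3)c2cn[nH]c(=O)c12` has not yet been measured. Set against compound 1 it carries 1,3-dimethyl-1H-pyrazol-4-yl in place of 1,3-dimethyl-1H-pyrazol-5-yl on an aromatic carbon; the two have the same atoms, joined differently. Among the compounds with values here, no pair of measured compounds isolates such a change, so the expected step, a 1.3-fold higher number from compound 1 to compound 4 (0.11 log units; within the scatter), is small and within the scatter, in either direction. For compound 4 the estimate is 1300 nM, with a range from 500 nM to 4000 nM.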

Compound 4, solubility: 9000 nM
Beside the measured number, compound 4's estimate is 6.9-fold (0.84 log units) below it; measured number outside the range, above it.
By their numbers in this assay, from the lowest: compound 1; then compound 3; then compound 4.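

Within the data shown here, the earlier compounds offered no pair differing in one place, so this is the first single change that can be read. In this assay, 1,3-dimethyl-1H-pyrazol-4-yl in place of 1,3-dimethyl-1H-pyrazol-5-yl gives a 9.0-fold higher number from compound 1 to compound 4 (0.95 log units; beyond the scatter), so how the ring is joined at this aromatic carbon matters even with the same atoms. Nothing measured here accounts for the step.

On these data alone, whether an amine or a carboxylic acid on this carbon would shift the number further stays open. So does whether the same exchange gives a similar step on another core.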